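This account rests on a few compounds, and the source may have more. Where it says the series, first, only, none or still open, it means among the compounds named here.

Measured so far:
compound 1, `CCCn1c(=O)c2[nH]c(-c3cnn(Cc4ccccc4)c3)nc2n(CCC)c1=O`, 11 nM
compound 2, `CCCn1c(=O)c2nc(-c3cnn(Cc4cc(C(F)(F)F)cc(Cl)c4F)c3)[nH]c2n(CCC)c1=O`, 360 nM
compound 3, `CCCn1c(=O)c2nc(-c3cnn(Cc4cccc(Cl)c4)c3)[nH]c2n(CCC)c1=O`, 18 nM

These three compounds share one core and differ only in the group carried on the saturated chain carbon bound to an aromatic nitrogen. In an in vitro assay on HEK293 cells for displacement of a labelled ligand from adenosine receptor A2b (Homo sapiens) (a higher number here means a weaker inhibitor, a lower number a stronger inhibitor), compound 3 gives 18 nM, the second highest of the three numbers. Its nearest neighbour is compound 1 with 11 nM, a gap that lies within the usual scatter, so the two cannot be told apart. Compound 2, with 360 nM, gives a clearly higher number than compound 3, a gap well beyond the scatter.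

Compound 4, `CCCn1c(=O)c2nc(-c3cnn(Cc4ccccc4C)c3)[nH]c2n(CCC)c1=O`, has not yet been measured. It differs from compound 3 in one place: 2-methylphenyl in place of 3-chlorophenyl on a saturated chain carbon bound to an aromatic nitrogen.

Going by the values given here, no step between measured compounds reports the effect of such a change on its own. Compound 1 and compound 3 show that a plain ring and a chlorine-bearing ring give numbers within scatter of each other, while compound 2 shows that a heavily substituted ring gives a much higher number. A single methyl is a modest change, so in this assay the expected step is small, with a slight lean toward a higher number, and likely within the scatter.

The step from compound 3 to compound 4 is expected to be a 1.4-fold higher number from compound 3 to compound 4 (0.14 log units; within the scatter).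

Compound 4 is therefore estimated to give 25 nM, within a range of 8 nM to 90 nM.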

Compound 4, inhibition constant: 33 nM
The estimate for compound 4 lay 1.3-fold (0.12 log units) below the measured number, and the stated range covers the measured number.
By their numbers in this assay, from the lowest: compounds 1, 3 and 4 (each within the scatter of the next, the first and the last beyond it); then compound 2.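

In this assay, going by these compounds alone, putting 2-methylphenyl in place of 3-chlorophenyl on a saturated chain carbon bound to an aromatic nitrogen gives a 1.8-fold higher number from compound 3 to compound 4 (0.26 log units; within the scatter) and is the first step to report a single change at this position. The chlorine-bearing ring and the methyl-bearing ring therefore cannot be told apart here, so a ring with one substituent at this position can carry either the 3-chlorobenzyl or the 2-methylbenzyl pattern without a step beyond the scatter. Nothing available accounts for the size of this step.

Going by these compounds, the step alters both the substituent and its place on the ring, so the contribution of each remains open, and 2-chlorophenyl or 3-methylphenyl would separate them. Also open, on these data alone, is how the ring would fare carrying an amine or a carboxylic acid.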